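The source may hold more compounds than are shown below. What is called first, only, known or untested is meant among the compounds shown, and "the series" means these compounds.

The measured compounds: compound 1 `Cc1c(CCCC(=O)O)c2cccc(/C=C/c3ccc(OCCCCc4c(F)c(F)cc(F)c4F)cc3)c2n1CC(=O)O`, which in a physicochemical assay for permeability, using PAMPA, with a stated time of 4 h, at pH 6.2, tested at 50 uM (a higher number here means that the compound crosses the layer faster, a lower number that the compound crosses the layer more slowly), gives 9.4 10^-6 cm/s; compound 2 `Cc1c(CCCC(=O)O)c2cccc(/C=C/c3ccc(OCCCCc4c(F)cc(F)c(F)c4F)cc3)c2n1CC(=O)O`, which in this assay gives 2.9 10^-6 cm/s; and compound 3 `Cc1c(F)cccc1CCCCOc1ccc(/C=C/c2cccc3c(CCCC(=O)O)c(C)n(CC(=O)O)c23)cc1`, which in this assay gives 4 10^-6 cm/s.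

Among these three numbers compound 3 stands second highest. Its nearest neighbour is compound 2, with a 1.4-fold higher number from compound 2 to compound 3 (0.14 log units; within the scatter), a gap within the scatter; compound 1 lies furthest away, with a 2.4-fold lower number from compound 1 to compound 3 (0.37 log units; beyond the scatter).

Compound 4 `Cc1c(F)cccc1CCCCOc1ccc(/C=C/c2cccc3c(CCCC(=O)O)cn(CC(=O)O)c23)cc1` differs from compound 3 in one place: hydrogen in place of methyl on an aromatic carbon. Within the data shown here, no measured step touches this position. The three steps known so far, a 3.2-fold lower number from compound 1 to compound 2 (0.51 log units; beyond the scatter), a 2.4-fold lower number from compound 1 to compound 3 (0.37 log units; beyond the scatter) and a 1.4-fold higher number from compound 2 to compound 3 (0.14 log units; within the scatter), all exchange the aryl group at the end of the chain, and they were modest or within the scatter. They give no direct guide to removing a methyl from the core, so the estimate rests on the number for compound 3 alone, widened for the uncertainty. For compound 4 no step beyond the scatter is expected, a 1.1-fold lower number from compound 3 to compound 4 (0.06 log units; within the scatter). Compound 4 is expected to give about 3.5 10^-6 cm/s, within a range from 1.6 10^-6 cm/s to 7.5 10^-6 cm/s.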

Compound 4, apparent permeability: 3.5 10^-6 cm/s
Compound 4: the middle estimate sits on the measured number at the digits printed; the range from low to high includes it.
By their numbers in this assay, from the lowest: compounds 2, 4 and 3 (each within the scatter of the next); then compound 1.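

Hydrogen in place of methyl on this aromatic carbon, next to the ring nitrogen, gives a 1.1-fold lower number from compound 3 to compound 4 (0.06 log units; within the scatter) in this assay. This is the first step shown on the shared core rather than on the aryl group at the end of the chain, and with 3-fluoro-2-methylphenyl at that end the methyl can go without a change beyond the scatter. Nothing measured here explains why the two numbers lie so close.

Going by these compounds, whether the same exchange behaves alike with the tetrafluorophenyl groups of compound 1 and compound 2 remains open. So does the outcome of placing an ethyl, a chlorine or an amine on this carbon, or of changing the 3-carboxypropyl or carboxymethyl groups on the neighbouring ring atoms.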